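This account rests on a few compounds, and the source may have more. Where it says the series, first, only, none or still open, it means among the compounds named here.

Series notes. Compound 1 `CC(C)(C)[C@H]1C(O)=C(C2=CS(=O)(=O)c3cc([N+](=O)[O-])ccc3N2)C(=O)N1Cc1ccc(F)cc1` and compound 2 `CC(=O)C1=C(C2=C(O)[C@H](C(C)(C)C)N(Cc3ccc(F)cc3)C2=O)Nc2ccc(NS(C)(=O)=O)cc2S1(=O)=O` have both been run in an ADME assay on 2209-23 cells (Homo sapiens) for cytotoxicity, read by WST assay and thymidine incorporation; on this read-out higher numbers stand for lower toxicity in this test and lower numbers for higher toxicity in this test. In this assay compound 1 gives > 50000 nM, which is a limit of the assay rather than a number. In this assay compound 2 gives > 50000 nM, likewise a limit. On the numbers shown, compound 1 therefore stands at the limit of > 50000 nM in this assay, at which 2 of the 2 values shown sit, and no separation between the two measured compounds can be read from them. Compound 3 `CC(C)(C)[C@H]1C(O)=C(C2=CS(=O)(=O)c3cc(C#N)ccc3N2)C(=O)N1Cc1ccc(F)cc1` has not yet been measured in this assay. It differs from compound 1 by cyano in place of nitro on an aromatic carbon. Among the measured compounds shown here, no measured step covers this change, so the two limits are the only footing. Compound 3 is expected to remain at the limit as well, with a step that the limit leaves unreadable from compound 1 to compound 3 expected, that is none beyond the scatter. The estimate for compound 3 in this assay is 60000 nM, within a range from 30000 nM to 150000 nM.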

Compound 3, half-maximal cytotoxic concentration: > 50000 nM
Compound 3 ended at the assay's limit (the forecaster's own chance of this, stated with the estimate: 85%); the middle value does not contradict the limit.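

No step can be read from compound 1 to compound 3 in this assay, because the values shown all stand at a single limit of the assay: the limit of > 50000 nM in this assay, at which 3 of the 3 values shown sit.

The compounds shown leave open how cyano and nitro on an aromatic carbon compare on this read-out, and where any of these compounds would turn toxic to the cells.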